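Swapping a Carbamate Cap for an Amide Cap

The source may hold more compounds than are shown below. What is called first, only, known or untested is meant among the compounds shown, and "the series" means these compounds.

Compound 1 `O=C(CN1CCNCC1)N1CCC(NS(=O)(=O)c2cc(S(=O)(=O)c3ccccc3)ccc2C(F)(F)F)CC1`: 250 nM
Compound 2 `CC(C)(C)OC(=O)N1CCC[C@@H]1C(=O)N1CCC(NS(=O)(=O)c2cc(S(=O)(=O)c3ccccc3)ccc2C(F)(F)F)CC1`: 210 nM

In a functional assay on U2OS cells for antagonist activity at proto-oncogene Wnt-3 (Homo sapiens), read by a luciferase reporter, with a stated time of 18 h (on this read-out higher numbers stand for an effect only at larger amounts of compound and lower numbers for an effect already at smaller amounts), compound 1 gives 250 nM and compound 2 gives 210 nM; the step of a 1.2-fold lower number from compound 1 to compound 2 (0.08 log units; within the scatter) shows the two sit within the scatter of each other. Compound 3 `CC(C)(C)C(=O)N1CCC[C@H]1C(=O)N1CCC(NS(=O)(=O)c2cc(S(=O)(=O)c3ccccc3)ccc2C(F)(F)F)CC1` differs from compound 2 by 1-((tert-butyl)carbonyl)pyrrolidin-2-yl in place of 1-(tert-butoxycarbonyl)pyrrolidin-2-yl on a carbonyl carbon. Among the measured compounds shown here, only the step from compound 1 to compound 2 bears on this site, and it was small. For compound 3 the step of a 1.0-fold higher number from compound 2 to compound 3 (0.02 log units; within the scatter) is therefore expected to stay within the scatter. Compound 3 is estimated at 220 nM, in the range 100 nM to 500 nM.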

Compound 3, half-maximal effective concentration: 270 nM
The estimate for compound 3 lay 1.2-fold (0.09 log units) below the measured number; the range from low to high includes it.
By their numbers in this assay, from the lowest: compounds 2, 1 and 3 (each within the scatter of the next).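

Putting 1-((tert-butyl)carbonyl)pyrrolidin-2-yl in place of 1-(tert-butoxycarbonyl)pyrrolidin-2-yl gives a 1.3-fold higher number from compound 2 to compound 3 (0.11 log units; within the scatter) in this assay and putting it in place of (piperazin-1-yl)methyl gives a 1.1-fold higher number from compound 1 to compound 3 (0.03 log units; within the scatter) in the same read-out. This site on the carbonyl carbon has now carried three different groups without a change beyond the scatter, and swapping the tert-butoxycarbonyl cap for the (tert-butyl)carbonyl cap leaves the number where it was. No measurement at hand offers an explanation for this.

Still open, on these data alone, is whether a pyrrolidine with a free amine, or a carboxylic acid on this site, would also leave the number unchanged.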